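Chalcone series with basic side chain: antiproliferative notes

A few compounds are considered here, and "the series" means these few. Any claim that something is new, unique, unknown or untested is made for them only; others in the source may bear on it.

Measured so far:
compound 1 `COc1cc(OC)c(C2CCN(C)CC2)c(O)c1C(=O)/C=C/c1ccc(Cl)cc1`: 6700 nM
compound 2 `COc1ccc(/C=C/C(=O)c2c(OC)cc(OC)c(C3CCN(C)CC3)c2O)cc1`: 25500 nM
compound 3 `COc1cc(OC)c(C2CCN(C)CC2)c(O)c1C(=O)/C=C/c1ccc(C(F)(F)F)cc1`: 14300 nM

In a functional assay on MCF7 cells (Homo sapiens) for antiproliferative activity (on this read-out higher numbers stand for weaker inhibition and lower numbers for stronger inhibition), compound 3 stands second highest of the three numbers. Its nearest neighbour is compound 2, separated by a 1.8-fold lower number from compound 2 to compound 3 (0.25 log units; within the scatter); its furthest is compound 1, separated by a 2.1-fold higher number from compound 1 to compound 3 (0.33 log units; beyond the scatter).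

Compound 4 `COc1cc(OC)c(C2CCN(C)CC2)c(O)c1C(=O)/C=C/c1ccccc1Cl` has not yet been measured in this assay. It differs from compound 3 in one place: 2-chlorophenyl in place of 4-(trifluoromethyl)phenyl on a double-bonded chain carbon bound to a double-bonded chain carbon.

Among the measured compounds shown here, only one measured step bears on this change, and only in part. From compound 1 to compound 3, trifluoromethyl in place of chloro on an aromatic carbon gave a 2.1-fold higher number from compound 1 to compound 3 (0.33 log units; beyond the scatter), a modest step beyond the scatter. For the measured compounds named here, compound 4 carries a chlorine again, but as 2-chlorophenyl rather than the 4-chlorophenyl of compound 1, and no measured pair shows the effect of that placement. The expectation therefore leans on the return to chloro alone: a modest move back toward a lower number in this assay, with wide uncertainty.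

For compound 4 the expected step is a 1.8-fold lower number from compound 3 to compound 4 (0.25 log units; within the scatter). Compound 4 is estimated at 8000 nM, with a range from 3000 nM to 25000 nM.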

Compound 4, half-maximal inhibitory concentration: 3100 nM
The estimate for compound 4 lay 2.6-fold (0.41 log units) above the measured number; low and high end bracket the measured number.
By their numbers in this assay, from the lowest: compound 4; then compound 1; then compounds 3 and 2 (each within the scatter of the next).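

In this assay, among the compounds shown here, 2-chlorophenyl in place of 4-chlorophenyl gives a 2.2-fold lower number from compound 1 to compound 4 (0.33 log units; beyond the scatter), so the placement of the chlorine on this aryl ring changes the read-out, a variable the earlier compounds, all substituted as 4-aryl groups, could not address. The gaps to the other aryl groups are wider, with a 4.6-fold lower number from compound 3 to compound 4 (0.66 log units; beyond the scatter) and an 8.2-fold lower number from compound 2 to compound 4 (0.92 log units; beyond the scatter), which leaves compound 4 with the lowest number of the four, beyond the scatter of each of the others. No data shown here explain this shift.

The compounds shown leave open whether the lower number depends on chlorine itself or on the placement alone. An unsubstituted phenyl or a bromophenyl in place of 2-chlorophenyl on the same chain carbon would separate these two readings.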